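Amide substituent series on a shared benzoxaborole core

This account rests on a few compounds, and the source may have more. Where it says the series, first, only, none or still open, it means among the compounds named here.

Measured in an ADME assay on WI-38 cells (Homo sapiens) for cytotoxicity, read by MTT assay, with a stated time of 72 h; a higher number here means a weaker inhibitor, a lower number a stronger inhibitor:
- compound 1, `O=C(CCc1cccc2c1B(O)OC2)NC1CCCCC1`, gives > 100000 nM, which is a limit of the assay.
- compound 2, `O=C(CCc1cccc2c1B(O)OC2)NCc1ccccc1`, gives > 100000 nM, also a limit of the assay.
- compound 3, `O=C(CCc1cccc2c1B(O)OC2)Nc1ccc(Br)cc1`, gives 42000 nM.

Among the measured compounds shown here, compound 3 holds the only actual number in this assay; the other two values are limits. The measured steps run an at least 2.3-fold lower number from compound 1 to compound 3 (0.37 log units; beyond the scatter) and an at least 2.3-fold lower number from compound 2 to compound 3 (0.37 log units; beyond the scatter), both beyond the scatter and both replacing a non-aromatic group on the amide nitrogen with 4-bromophenyl. The step that the two limits leave unreadable from compound 1 to compound 2 cannot be read.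

Compound 4, `COc1ccc(NC(=O)CCc2cccc3c2B(O)OC3)cc1`, differs from compound 3 by methoxy in place of bromo on an aromatic carbon. For the measured compounds named here, no measured step changes only a substituent on that aromatic ring, so the two steps into compound 3 bear on it only loosely: they show an aryl amide is the one compound giving a number. For compound 4 the step of a 1.4-fold higher number from compound 3 to compound 4 (0.15 log units; within the scatter) is expected to stay within the scatter, and compound 4 is estimated at 60000 nM, with a range of 25000 nM to 150000 nM.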

Compound 4, half-maximal inhibitory concentration: > 100000 nM
Compound 4 was reported as a limit; the forecaster's own chance of this, stated with the estimate: 35%; middle value at least 1.6-fold (0.22 log units) from the limit.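

Among the compounds shown here, this is the first change read at this position, on an aromatic carbon para to a large group: methoxy in place of bromo gives an at least 2.3-fold higher number from compound 3 to compound 4 (0.37 log units; beyond the scatter). An aryl amide alone therefore does not secure a measured number, since compound 4 has one and still reads as a limit. The size of the step stays open because compound 4 sits at a limit: the limit of > 100000 nM in this assay, at which 3 of the 4 values shown sit.

From the compounds shown here alone, whether chloro or an amine at this position would give a number, as compound 3 does, remains open. Also open, going by these compounds, is whether bromo elsewhere on this ring would do the same.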